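A few compounds are considered here, and "the series" means these few. Any claim that something is new, unique, unknown or untested is made for them only; others in the source may bear on it.

In an assay for binding affinity to dual specificity mitogen-activated protein kinase kinase 4 (Homo sapiens), read by KINOMEscan, tested at 100 nM (a higher number here means a weaker effect of the compound at the concentration tested, a lower number a stronger effect), three compounds built on one shared core have been measured. Compound 2 `CCCS(=O)(=O)Nc1ccc(F)c(C(=O)c2n[nH]c3ncc(-c4ccccc4F)cc23)c1F` gives 2%, the lowest of the three numbers as written, though compound 1 `CCCS(=O)(=O)Nc1ccc(F)c(C(=O)c2n[nH]c3ncc(-c4ccccc4Cl)cc23)c1F` with 9.3% sits so close that the step of a number 7.3 percentage points lower from compound 1 to compound 2 (within the scatter) cannot separate the two. Compound 3 `CCCS(=O)(=O)Nc1ccc(F)c(C(=O)c2n[nH]c3ncc(-c4cccc(C)c4)cc23)c1F` gives 15%; the step of a number 13 percentage points higher from compound 2 to compound 3 (beyond the scatter) is beyond the scatter, while a number 5.7 percentage points higher from compound 1 to compound 3 (within the scatter) is not. Compound 4 `CCCS(=O)(=O)Nc1ccc(F)c(C(=O)c2n[nH]c3ncc(-c4ccccc4OC)cc23)c1F` has not yet been measured. It differs from compound 2 by methoxy in place of fluoro on an aromatic carbon. For the measured compounds named here, the only measured step that swaps one single group for another on that aromatic carbon, a number 7.3 percentage points lower from compound 1 to compound 2 (within the scatter), stayed within the scatter, so such an exchange has so far moved the read-out little. Here, however, two heavy atoms and one hydrogen-bond acceptor enter where one fluorine leaves, a change the measured steps do not cover. The expectation is therefore a small step, a number 6 percentage points higher from compound 2 to compound 4 (within the scatter), upward if anything. Compound 4 is expected to give about 8%, between 1% and 25%.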

Compound 4, a percentage reported as activity, at one concentration (the size of the read-out at that concentration, not a potency): 1.9%
Beside the measured number, compound 4's estimate is 6.1 percentage points above it, within the range that was stated.
By their numbers in this assay, from the lowest: compounds 4, 2, 1 and 3 (each within the scatter of the next, the first and the last beyond it).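

At this place on the ring, ortho to a large group, methoxy reads no differently from fluoro in this assay (a number 0.1 percentage points lower from compound 2 to compound 4 (within the scatter)) or from chloro (a number 7.4 percentage points lower from compound 1 to compound 4 (within the scatter)), so the extra heavy atom and the hydrogen-bond acceptor leave the read-out where the single halogen atoms put it. Compound 4 also gives a second step beyond the scatter from the 3-methylphenyl compound (a number 13.1 percentage points lower from compound 3 to compound 4 (beyond the scatter)), although compound 1 stays within the scatter of compound 3, and this step changes both the group and where it sits, so neither change can be credited alone. Nothing measured here explains why these groups read alike.

As far as these compounds go, it remains open whether this place would also accept an amine, a carboxylic acid or a longer chain such as butoxy. From the compounds shown here alone, it is equally open whether methoxy would read the same on another carbon of this ring.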